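Removing a Methyl Between Two Ring Nitrogens

A few compounds are considered here, and "the series" means these few. Any claim that something is new, unique, unknown or untested is made for them only; others in the source may bear on it.

Compound 1 `Cc1ncc(C)c(-c2ccccc2)n1` gives 12%.
Compound 2 `Cc1cncnc1-c1ccccc1` gives 48%.
Compound 3 `Cc1nnc2c(n1)CC(C(C)(C)C)CC2` gives a limit of the assay, < 5%.

In a functional assay on the whole organism for inhibition, with Rattus norvegicus as the target, with stated times of 1 h and 3.5 h, at a dose of 100 mg/kg by the oral route (on this read-out higher numbers stand for more inhibition at the one dose given (going by the name of the read-out) and lower numbers for less inhibition), compound 1 gives 12%, while compound 2 gives 48%. The change between them is hydrogen in place of methyl on an aromatic carbon, and it made a step of a number 36 percentage points higher from compound 1 to compound 2 (beyond the scatter). For compound 3 the read-out is only a limit of the assay, < 5%; this is the limit of < 5% in this assay, at which 1 of the 3 values shown sits. How the core of compound 3 differs from that of compound 1 is not broken down here.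

Compound 4 `CC(C)(C)C1CCc2nncnc2C1` has not yet been tested. It differs from compound 3 by hydrogen in place of methyl on an aromatic carbon, the same kind of change as from compound 1 to compound 2, though the surroundings differ: here the carbon sits in a six-membered aromatic ring with 3 nitrogen, part of a fused system of two rings, meta and para to a fused ring, whereas in compound 1 it sits in a ring with 2 nitrogen, meta to a group of 6 heavy atoms and para to a methyl group. Resting on a number 36 percentage points higher from compound 1 to compound 2 (beyond the scatter), the expected step from compound 3 to compound 4 is a number at least 10 percentage points higher from compound 3 to compound 4 (that floor lies within the scatter), kept modest because compound 3 starts at a limit, < 5%. Compound 4 is therefore estimated at 15%, between 3% and 35%.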

Compound 4, a percentage reported as inhibition, in the whole organism at one dose (the size of the read-out at that dose, not a potency): 49%
The estimate for compound 4 lay 34 percentage points below the measured number; measured number above the stated range.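

In this assay, hydrogen in place of the methyl between two ring nitrogen atoms gave a number at least 44 percentage points higher from compound 3 to compound 4 (beyond the scatter). Compound 3 gives < 5%, which is a limit of the assay and not a number. The change raised the read-out on both cores shown, which is two cases and not a rule for the series, and the size of its effect cannot be compared between them: the same change on two cores in this assay, a number 36 percentage points higher (beyond the scatter) from compound 1 to compound 2 and a number at least 44 percentage points higher (beyond the scatter) from compound 3 to compound 4; the limit leaves it open whether they differ

The compounds shown leave open how an amine or a longer chain at that place would compare with hydrogen and methyl. They also leave open whether the same change would raise the read-out on any further core.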